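The compounds below may be only part of what the source reports. "The series", "measured", "known", "first", "only" and "open" are said of these compounds alone.

Measured in a physicochemical assay for solubility; on this read-out lower numbers stand for lower solubility and higher numbers for higher solubility:
- compound 1 `CNC(=O)c1cc(C(=O)N[C@H]2[C@@H]3COC[C@@H]32)cc2c1OC[C@H]2c1ccccc1`: >= 165 ug/mL, a limit
- compound 2 `CNC(=O)c1cc(C(=O)N[C@H]2[C@@H]3C[C@@H](O)C[C@@H]32)cc2c1OC[C@H]2c1ccccc1`: >= 124 ug/mL, a limit
- compound 3 `CNC(=O)c1cc(C(=O)NC2CC2)cc2c1OC[C@H]2c1ccccc1`: >= 190 ug/mL, a limit

Compound 1 stands with a limit only, not an exact number, and the other two compounds are no different. Compound 4 `CNC(=O)c1cc(C(=O)N[C@H]2[C@@H]3COC[C@@H]32)cc2c1OC[C@H]2C1CCOCC1` keeps the core of compound 1 and changes one group on a saturated ring carbon: oxan-4-yl in place of phenyl on a saturated ring carbon. The measured steps a step that the two limits leave unreadable from compound 1 to compound 2, a step that the two limits leave unreadable from compound 1 to compound 3 and a step that the two limits leave unreadable from compound 2 to compound 3 all concern the group on an amide-type nitrogen, and their sizes cannot be read. They give no size for this change, so no step beyond the usual scatter is expected in this assay, and another limit is likely. The estimate means a step that the limit leaves unreadable from compound 1 to compound 4. For compound 4 the expected value is 170 ug/mL, within an estimated range from 100 ug/mL to 280 ug/mL.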

Compound 4, solubility: >= 177 ug/mL
Compound 4 ended at the assay's limit; the forecaster's own chance of this, stated with the estimate: 70%; middle value at least 1.0-fold (0.01 log units) away from the limit.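

In this assay, within the data shown here, compound 1 and compound 4 both stand only as limits, so no step between them can be read. The compounds shown leave open the exact values, and whether oxan-4-yl in place of phenyl shifts the read-out at all.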